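This account rests on a few compounds, and the source may have more. Where it says the series, first, only, none or still open, it means among the compounds named here.

Compound 1 `Nc1ccccc1NC(=O)c1ccc(CSC(=S)N2CCN(c3ccc(Cl)cc3)CC2)cc1` and compound 2 `Nc1ccccc1NC(=O)c1ccc(CSC(=S)N2CCN(c3ncccn3)CC2)cc1` share a core and differ only in the group on the amine nitrogen of the piperazine ring. In a functional assay on HeLa cells (Homo sapiens) for antiproliferative activity, read by CCK-8 assay, with a stated time of 72 h, tested at 8 uM (a higher number here means a stronger effect of the compound at the concentration tested, a lower number a weaker effect), compound 1 gives 44.8%, and compound 2 gives 73.9%. Within the data shown here, the single step within the pair, a number 29.1 percentage points higher from compound 1 to compound 2 (beyond the scatter), is the only measured change at this position. On these two numbers compound 2 stands highest, with compound 1 as its nearest neighbour, lower by a margin that exceeds the scatter.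

Compound 3 `Nc1ccccc1NC(=O)c1ccc(CSC(=S)N2CCN(Cc3cccnc3)CC2)cc1` is the next compound in this series. It differs from compound 2 in one place: (pyridin-3-yl)methyl in place of pyrimidin-2-yl on an amine nitrogen in a ring. The measured step from compound 1 to compound 2 bears on this change only loosely, since it exchanged one aromatic ring attached directly to the ring nitrogen for another, whereas here the ring is attached through a methylene. The size of that step shows that this position can move the read-out in this assay by a modest amount. Among the measured compounds shown here, no measured step tells which way a benzylic-type attachment would go, so the expectation is wide. Compound 3 is estimated at 58%, within a range from 35% to 80%, meaning an expected step of a number 15.9 percentage points lower from compound 2 to compound 3 (beyond the scatter).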

Compound 3, a percentage reported as inhibition, at one concentration (the size of the read-out at that concentration, not a potency): 78%
Beside the measured number, compound 3's estimate is 20 percentage points below it; the range from low to high includes it.
By their numbers in this assay, from the lowest: compound 1; then compounds 2 and 3 (each within the scatter of the next).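

In this assay the exchange of pyrimidin-2-yl for (pyridin-3-yl)methyl on an amine nitrogen in a ring gives a number 4.1 percentage points higher from compound 2 to compound 3 (within the scatter) and so leaves the read-out level, which shows that this position tolerates an aromatic ring held through a methylene as well as one attached directly to the nitrogen. Set against the 4-chlorophenyl group, the same (pyridin-3-yl)methyl group gives a number 33.2 percentage points higher from compound 1 to compound 3 (beyond the scatter) and so places a second, differently attached ring with a ring nitrogen apart from compound 1 in the same direction as pyrimidin-2-yl, which means that the step first seen at this position is not tied to pyrimidin-2-yl alone. No measurement offered here accounts for either the level pair or the larger step.

The three compounds leave open whether the ring nitrogen or the methylene carries the difference from compound 1, a question that a plain benzyl group, a 4-chlorobenzyl group or a longer chain such as 2-(pyridin-3-yl)ethyl would address. Each read-out also comes from a single concentration, so whether the effects of compound 2 and compound 3 would also match at other concentrations remains unsettled.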